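The source may report more compounds than this note shows. Statements on the series, on what has been measured and on what is new or still open speak of the compounds shown alone.

Compound 1 `CN(C)C1=NN(c2ccccc2)CN(c2ccccc2Cl)C1=O` gives 39.5 ug/mL
Compound 2 `O=C1C(N2CCCCC2)=NN(c2ccc(Cl)cc2)CN1c1ccccc1Cl` gives > 50 ug/mL as a limit of the assay

For the measured compounds named here, in a functional assay on HeLa cells (Homo sapiens) for cytotoxicity, with a stated time of 72 h (on this read-out higher numbers stand for lower toxicity in this test and lower numbers for higher toxicity in this test), compound 1 gives 39.5 ug/mL as the only actual number so far, which leaves it with no measured compound to be ranked against. Compound 2 is reported as > 50 ug/mL and this is a limit, not a number.

Compound 3 `O=C1C(N2CCCC2)=NN(c2ccccc2)CN1c1ccccc1Cl` has not yet been measured. It keeps the core of compound 1 and carries pyrrolidin-1-yl in place of dimethylamino on a carbon with a double bond to nitrogen in the shared core. Going by the values given here, no measured pair of compounds shows what this exchange does, so the expectation in this assay starts from compound 1 at 39.5 ug/mL and foresees no step beyond the scatter in either direction. The expected step of a 1.0-fold higher number from compound 1 to compound 3 (0.01 log units; within the scatter) is therefore small, and a report of compound 3 as a limit would not be surprising. For compound 3 the estimate is 40 ug/mL as the expected middle, within an expected range from 22 ug/mL to 50 ug/mL on this read-out.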

Compound 3, half-maximal cytotoxic concentration: 44.3 ug/mL
The estimate for compound 3 lay 1.1-fold (0.04 log units) below the measured number; the range from low to high includes it.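

In this assay, for the compounds shown here, pyrrolidin-1-yl in place of dimethylamino on a carbon with a double bond to nitrogen gives a 1.1-fold higher number from compound 1 to compound 3 (0.05 log units; within the scatter), so this pair provides the first step that can be read at this position. The change adds a five-membered non-aromatic ring where there was no ring, yet compound 1 and compound 3 cannot be told apart in this assay; this holds for this one pair and sets no rule for other groups at this place. Compound 2 offers no number to set beside this pair, as its value is a limit: the limit of > 50 ug/mL in this assay, at which 1 of the 3 values shown sits.

From the compounds shown here alone, what remains open is whether any group at this place would move the read-out beyond the scatter, for instance morpholin-4-yl, 4-methylpiperazin-1-yl, a primary amine or a longer chain such as dipropylamino. Compound 2 differs from compound 1 in more than one place, so the separate contributions of piperidin-1-yl and of the chlorine on its phenyl group also stay unresolved.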